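The source may report more compounds than this note shows. Statements on the series, on what has been measured and on what is new or still open speak of the compounds shown alone.

Working notes on the series. Compound 1 `CCOC(=O)CN(Cc1ccccc1)c1nc(NCc2ccccc2)ncc1[N+](=O)[O-]` and compound 2 `CCOC(=O)CN(Cc1ccccc1)c1nc(NCc2cccc(OC)c2)ncc1[N+](=O)[O-]` share one core; compound 3 `COC(=O)CN(C)c1nc(Nc2cccc(OC)c2)ncc1[N+](=O)[O-]` and compound 4 `COC(=O)CN(C)c1nc(Nc2ccccc2)ncc1[N+](=O)[O-]` share another, and the difference between the two cores is not broken down here.

In a functional assay on MCF7 cells (Homo sapiens) for antiproliferative activity, read by MTT assay, with a stated time of 48 h (on this read-out higher numbers stand for weaker inhibition and lower numbers for stronger inhibition), compound 2 gives 57400 nM. Compound 1 reaches only a limit of the assay, > 100000 nM; this is the limit of > 100000 nM in this assay, at which 1 of the 3 values shown sits. The change from compound 2 to compound 1 is hydrogen in place of methoxy on an aromatic carbon, and it made an at least 1.7-fold higher number from compound 2 to compound 1 (0.24 log units; that floor lies within the scatter).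

In this assay compound 3 gives 93700 nM. The change from compound 3 to compound 4 is hydrogen in place of methoxy on an aromatic carbon, the same kind of change, with both place descriptions reading alike.

An expected step of the same direction, a 1.6-fold higher number from compound 3 to compound 4 (0.20 log units; within the scatter), rests on compound 1 standing at the limit of > 100000 nM in this assay, at which 1 of the 3 values shown sits, after the matching change. Compound 4 is therefore estimated at 150000 nM, expected between 60000 nM and 400000 nM, with a fair chance that only a limit is reported.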

Compound 4, half-maximal inhibitory concentration: > 100000 nM
Compound 4: only a limit was reported; the forecaster's own chance of this, stated with the estimate: 65%; the middle value does not contradict the limit.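

In this assay, hydrogen in place of methoxy, read on this core as 3-methoxyphenyl to phenyl, gives an at least 1.0-fold higher number from compound 3 to compound 4 (0.02 log units; that floor lies within the scatter). Both steps are floors that lie within the scatter, so they show no measured loss on either core, and their sizes cannot be compared: the same change on two cores in this assay, an at least 1.7-fold higher number (0.24 log units; that floor lies within the scatter) from compound 2 to compound 1 and an at least 1.0-fold higher number (0.02 log units; that floor lies within the scatter) from compound 3 to compound 4; the limit leaves it open whether they differ. The result therefore neither confirms nor rules out that the change carries from one core to the other, and much of the series rests on a single ceiling: the limit of > 100000 nM in this assay, at which 2 of the 4 values shown sit.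

The compounds shown leave open whether a fluorine or a hydroxy group on the same aromatic ring would bring a value clear of that limit. Also open, from the compounds shown here alone, is what a carboxylic acid in place of the ester would do.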